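Working notes: from compound 2 to compound 3

The source may report more compounds than this note shows. Statements on the series, on what has been measured and on what is new or still open speak of the compounds shown alone.

Of the compounds shown here, two have been read in a functional assay on MDA-MB-231 cells (Homo sapiens) for antiproliferative activity, read by MTT assay, with a stated time of 24 h; on this read-out lower numbers stand for stronger inhibition and higher numbers for weaker inhibition. Compound 1 (`O=C(NNc1ccc(F)cc1)c1ccc(NS(=O)(=O)c2cnc(O)nc2O)cc1`) gives > 20000 nM, which is a limit of the assay and not a number. Among the measured compounds shown here, compound 2 (`O=C(NNc1cccc(Cl)c1)c1ccccc1NS(=O)(=O)c1cnc(O)nc1O`) gives 11800 nM, the only actual number so far in this assay.

Compound 3 (`Cc1ccccc1C(=O)NNC(=O)c1ccccc1NS(=O)(=O)c1cnc(O)nc1O`) has not yet been measured. It differs from compound 2 in one place: (2-methylphenyl)carbonyl in place of 3-chlorophenyl on an amine nitrogen. In words, (2-methylphenyl)carbonyl stands in place of 3-chlorophenyl on an amine nitrogen whose other neighbour is an amide-type nitrogen.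

For the measured compounds named here, no measured step covers this change, so any expectation is anchored only on compound 2 at 11800 nM. A small shift towards weaker inhibition is expected, possibly no larger than the usual scatter, and compound 3 may be reported only as a limit. The estimated move is a 1.3-fold higher number from compound 2 to compound 3 (0.10 log units; within the scatter). For compound 3 the expected value is 15000 nM, with an estimated range of 6000 nM to 35000 nM.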

Compound 3, half-maximal inhibitory concentration: 5570 nM
Estimate against measurement, compound 3: 2.7-fold (0.43 log units) above, outside the stated range (below it).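

In this assay, (2-methylphenyl)carbonyl in place of 3-chlorophenyl on an amine nitrogen gives a 2.1-fold lower number from compound 2 to compound 3 (0.33 log units; beyond the scatter), so this position is the first in the series shown to respond to a change of group. The step is modest, but it shows that a carbonyl can stand on this nitrogen in place of a directly attached aromatic ring without a move towards weaker inhibition, while the entering group keeps a six-membered aromatic ring of carbon only. Compound 2 and compound 3 both give actual numbers, so the step is read between two values and not against the limit of the assay: the limit of > 20000 nM in this assay, at which 1 of the 3 values shown sits.

The single step changes three things at once: the carbonyl enters, chlorine gives way to methyl, and the substituent on the ring changes its place, so the compounds shown cannot say which of these accounts for the lower number. Unsubstituted benzoyl or (3-chlorophenyl)carbonyl on the same nitrogen would separate these changes, and a carboxylic acid or an amine on the ring would test how far the position tolerates other groups.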